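The source may report more compounds than this note shows. Statements on the series, on what has been measured and on what is new or still open speak of the compounds shown alone.

Values in a functional assay on A549 cells (Homo sapiens) for antiproliferative activity, read by MTT assay, with a stated time of 48 h; a lower number here means a stronger inhibitor, a higher number a weaker inhibitor:
- compound 1 `Cc1ccc(C(=O)/C=C/c2cc(Cl)cc(Cl)c2Oc2c([N+](=O)[O-])cc(C(F)(F)F)cc2[N+](=O)[O-])cc1`: 10.1 ug/mL
- compound 2 `COc1ccc(C(=O)/C=C/c2cc(Cl)cc(Cl)c2Oc2c([N+](=O)[O-])cc(C(F)(F)F)cc2[N+](=O)[O-])cc1`: 12.6 ug/mL

Compound 2 has a single measured neighbour, and the two values lie within the scatter of each other. Compound 3 `O=C(/C=C/c1cc(Cl)cc(Cl)c1Oc1c([N+](=O)[O-])cc(C(F)(F)F)cc1[N+](=O)[O-])c1ccc(F)cc1` has not yet been measured. The change leading to it is fluoro in place of methoxy on an aromatic carbon, para to a large group.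

Among the measured compounds shown here, only one measured step bears on this, and it concerns the same aromatic carbon: a 1.2-fold higher number from compound 1 to compound 2 (0.10 log units; within the scatter). That step exchanges methyl for methoxy and stays within the scatter. For the measured compounds named here, no fluoro compound has been measured, so it is only a weak guide. No clear direction is expected in this assay, and no change beyond the scatter. The expected step is a 1.1-fold lower number from compound 2 to compound 3 (0.06 log units; within the scatter). For compound 3 the estimated value is 11 ug/mL, with an expected range of 5 ug/mL to 24 ug/mL.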

Compound 3, half-maximal inhibitory concentration: 29.4 ug/mL
For compound 3 the middle estimate is 2.7-fold (0.43 log units) below the measured one; measured number outside the range, above it.
By their numbers in this assay, from the lowest: compounds 1 and 2 (each within the scatter of the next); then compound 3.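

In this assay this aromatic carbon, para to a large group, turns out not to be indifferent to its substituent: fluoro gives a 2.3-fold higher number from compound 2 to compound 3 (0.37 log units; beyond the scatter), and a 2.9-fold higher number from compound 1 to compound 3 (0.46 log units; beyond the scatter), both modest, whereas methyl and methoxy had stayed within the scatter of each other. Compound 3 is therefore the weakest inhibitor of the three, and the two steps that separate it share the same entering group, so the series now shows a real difference at this position, though it rests on a single fluoro compound. Nothing available accounts for this difference.

On these data alone, whether the weaker result is particular to fluoro or extends to other groups on this carbon remains open. Chloro, hydroxyl, an amine or a carboxylic acid here would help settle that, as would the compound carrying only hydrogen.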